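Chain shortening and the step to compound 4

The compounds below may be only part of what the source reports. "The series", "measured", "known", "first", "only" and "open" are said of these compounds alone.

Values in a functional assay on MDA-MB-231 cells (Homo sapiens) for inhibition, read by MTT assay, with a stated time of 48 h (on this read-out higher numbers stand for weaker inhibition and lower numbers for stronger inhibition), for the measured compounds
- compound 1 `COc1ccc(N(C)c2nc(C)nc3ccccc23)cc1OCCCCCC[Se]C#N` gives 3550 nM
- compound 2 `COc1ccc(N(C)c2nc(C)nc3ccccc23)cc1OCC[Se]C#N` gives 13 nM
- compound 3 `COc1ccc(N(C)c2nc(C)nc3ccccc23)cc1OCCCC[Se]C#N` gives 1350 nM

Compound 3 holds the second highest of the three numbers, with compound 1 nearest and compound 2 furthest. The next structure is compound 4 `COc1ccc(N(C)c2nc(C)nc3ccccc23)cc1C[Se]C#N` and its change is a group of 4 heavy atoms (2 carbon, 1 nitrogen, 1 selenium; no ring) in place of a group of 8 heavy atoms (5 carbon, 1 nitrogen, 1 oxygen, 1 selenium; no ring), on an aromatic carbon on an aromatic carbon, ortho to a methoxy group. Among the three measured compounds the number falls as the chain shortens, and none goes against this. The falls are unequal, with the modest 2.6-fold lower number from compound 1 to compound 3 (0.42 log units; beyond the scatter) set against the large 100-fold higher number from compound 2 to compound 3 (2.02 log units; beyond the scatter) and the large 270-fold lower number from compound 1 to compound 2 (2.44 log units; beyond the scatter) in the same read-out. These steps bear on the change only in part. Within the data shown here, no measured compound lacks the oxygen that leaves here. The expectation rests on compound 2 at 13 nM as the shortest measured chain. The estimate means a 17-fold lower number from compound 3 to compound 4 (1.23 log units; beyond the scatter) in this assay as an expected large step to a lower number. Compound 4 is estimated at 80 nM with 10 nM to 900 nM as the expected range.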

Compound 4, half-maximal inhibitory concentration: 153 nM
For compound 4 the middle estimate is 1.9-fold (0.28 log units) below the measured one; the range from low to high includes it.
By their numbers in this assay, from the lowest: compound 2; then compound 4; then compound 3; then compound 1.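

Among these compounds, with the ether oxygen gone and the group of 4 heavy atoms on the aromatic carbon, the number in this assay does not rise, with an 8.8-fold lower number from compound 3 to compound 4 (0.95 log units; beyond the scatter) and a 23-fold lower number from compound 1 to compound 4 (1.37 log units; beyond the scatter) as the two steps down, so this position accepts a change that none of the earlier compounds carried. Among the compounds shown here, the oxygen-bearing shorter chain still holds the lowest number, with a 12-fold higher number from compound 2 to compound 4 (1.07 log units; beyond the scatter) on this read-out, so compound 4 goes against the fall with shortening seen in the earlier compounds, and the shortest group here does not give the lowest number. No measurement at hand accounts for these differences.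

The separate shares of the lost oxygen and of the chain length remain unresolved across these compounds. As far as these compounds go, it remains open whether an amine in place of the ether oxygen, or a longer chain on the aromatic carbon without that oxygen, would bring the number near that of compound 2 at 13 nM in this assay or move it away.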